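The compounds below may be only part of what the source reports. "The series", "measured", "known", "first", "only" and "open" are said of these compounds alone.

Of the compounds shown here, three built on a shared core have been measured in an assay on isolated protein for displacement of a labelled ligand from metabotropic glutamate receptor 5 (Homo sapiens), with a stated time of 60 min, tested at 1 uM; on this read-out lower numbers stand for less inhibition and higher numbers for more inhibition at the one concentration tested (going by the name of the read-out). Compound 1, `CC1CCN(c2c(S(=O)(=O)c3cccc(Cl)c3)cnc3ccc(Cl)cc23)CC1`, gives 92%. Compound 2, `COc1ccc(S(=O)(=O)c2cnc3cc(F)ccc3c2N2CCC(C)CC2)cc1`, gives 90%. Compound 3, `Cc1ccc(S(=O)(=O)c2cnc3cc(Cl)ccc3c2N2CCC(C)CC2)cc1`, gives 94%. Compound 2 therefore sits alongside the other two rather than apart from them: the gap between its number and that of compound 1, and the gap between its number and that of compound 3, both fall within the usual scatter of repeated measurements, so the three results read as one common level and not as a ranking.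

The unmeasured compound 4, `CC1CCN(c2c(S(=O)(=O)c3ccc(F)cc3)cnc3cc(F)ccc23)CC1`, differs from compound 2 in a single place: fluoro in place of methoxy on an aromatic carbon. Within the data shown here, no measured pair shows exactly this exchange, so there is no directly comparable step to lean on. What the measured compounds do show is that the six-membered aromatic ring of carbon only already carries different substituents across compounds 1, 2 and 3 while the numbers stay within the scatter of one another. On that basis the step of a number 1 percentage points lower from compound 2 to compound 4 (within the scatter) is expected to be no more than the scatter, with no clear direction. Compound 4 is estimated at 89%, within a range from 80% to 96%.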

Compound 4, a percentage reported as inhibition, at one concentration (the size of the read-out at that concentration, not a potency): 74.5%
The estimate for compound 4 lay 14.5 percentage points above the measured number; measured number outside the range, below it.
By their numbers in this assay, from the lowest: compound 4; then compounds 2, 1 and 3 (each within the scatter of the next).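

The step of a number 15.5 percentage points lower from compound 2 to compound 4 (beyond the scatter) in this assay is the only change in one place among these compounds, and it lies beyond the scatter. It shows that the group on the aromatic carbon para to a large group can matter, even though the three earlier results read as one common level and gave no sign of this. The exchange swaps methoxy for fluoro, which leaves one heavy atom in place of two and one hydrogen-bond acceptor fewer, but no measurement here links either difference to the lower number.

A single exchange cannot tell whether the drop comes from losing methoxy or from gaining fluoro, and an unsubstituted ring carbon, a hydroxyl, an ethoxy or an amine at this position would help separate the two. Going by these compounds, it also remains open whether the same exchange would have a similar effect with a chloro in place of the fluoro on the shared core, or with the sulfonyl-bound ring substituted at another position.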